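Allyl, propyl and ethynyl variants on the shared core

The compounds below may be only part of what the source reports. "The series", "measured", "known", "first", "only" and "open" are said of these compounds alone.

compound 1 `C=CCc1cc(C(=O)N[C@H](C)CCCc2cccnc2)ccc1-c1ccc(OC)c(OC)c1` gives 80 nM in an assay (Canis lupus familiaris) for binding affinity to platelet-activating factor receptor (Homo sapiens), read by radioligand binding; on this read-out higher numbers stand for weaker inhibition and lower numbers for stronger inhibition
compound 2 `CCCc1cc(C(=O)N[C@H](C)CCCc2cccnc2)ccc1-c1ccc(OC)c(OC)c1` gives 50 nM in this assay
compound 3 `Cc1cccc(-c2ccc(C(=O)NCCCCc3cccnc3)cc2)c1` gives 500 nM in this assay

Compound 2 shows the lowest number of the three in this assay. Compound 1 lies within the scatter of it, so the two cannot be ordered; compound 3, with 500 nM, lies beyond the scatter from compound 2 and is the weakest of the set.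

Compound 4 `C#Cc1cc(C(=O)N[C@H](C)CCCc2cccnc2)ccc1-c1ccc(OC)c(OC)c1` is unmeasured. The change from compound 2 is ethynyl in place of propyl on an aromatic carbon. Among the measured compounds shown here, the only measured step touching this arm is a 1.6-fold lower number from compound 1 to compound 2 (0.20 log units; within the scatter), in which ethyl replaced vinyl; it stayed within the scatter, suggesting that the degree of saturation of this chain moves the number little. For the measured compounds named here, no measured step covers shortening the chain or introducing a triple bond, so the present change is only partly anchored.

The expectation for compound 4 is therefore a modest step, a 1.6-fold higher number from compound 2 to compound 4 (0.20 log units; within the scatter), possibly none beyond the scatter. Compound 4 is estimated at 80 nM, with a range of 30 nM to 250 nM.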

Compound 4, half-maximal inhibitory concentration: 5 nM
Compound 4: the middle estimate sits 16-fold (1.20 log units) above what was measured, and the stated range ends above it.
By their numbers in this assay, from the lowest: compound 4; then compounds 2 and 1 (each within the scatter of the next); then compound 3.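

In this assay, the substituent on this aromatic carbon, ortho to a 3,4-dimethoxyphenyl group, can move the number well beyond the scatter: ethynyl in place of propyl gives a 10-fold lower number from compound 2 to compound 4 (1.00 log units; beyond the scatter), and ethynyl in place of allyl gives a 16-fold lower number from compound 1 to compound 4 (1.20 log units; beyond the scatter). The earlier step between the two unbranched chains, a 1.6-fold lower number from compound 1 to compound 2 (0.20 log units; within the scatter), stayed within the scatter and gave no sign of this sensitivity, so the insensitivity seen there does not extend to ethynyl. No measurement bears on what lies behind the change.

The compounds shown leave open whether the triple bond or the shorter substituent accounts for the step. A plain ethyl group on this carbon would separate the two, and a propynyl group would show whether the triple bond keeps the low number in a longer chain.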